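The compounds below may be only part of what the source reports. "The series", "measured", "known", "first", "only" and "open" are said of these compounds alone.

Measured compounds:
compound 1 `COc1ccc(C(=O)Nc2ccccc2O)cc1OC1CCCC1` gives 1300 nM in an assay on isolated protein for inhibition of phosphodiesterase 4A (Sus scrofa); a higher number here means a weaker inhibitor, a lower number a stronger inhibitor
compound 2 `COc1ccc(C(=O)Nc2ccncc2)cc1OC1CCCC1` gives 800 nM in this assay

Within the data shown here, compound 2 stands within the scatter of compound 1 in this assay; the single measured step, a 1.6-fold lower number from compound 1 to compound 2 (0.21 log units; within the scatter), shows no separation between the two. Compound 3 `COc1ccc(C(=O)Nc2nccs2)cc1OC1CCCC1` differs from compound 2 by 1,3-thiazol-2-yl in place of pyridin-4-yl on an amide-type nitrogen. The step from compound 1 to compound 2 also exchanged the group on the amide-type nitrogen and stayed within the scatter, but it involved different groups and bears only loosely on this exchange. The expected step is therefore none beyond the scatter, a 1.1-fold lower number from compound 2 to compound 3 (0.06 log units; within the scatter). For compound 3 the estimate in this assay is 700 nM, within 200 nM to 2500 nM.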

Compound 3, half-maximal inhibitory concentration: 6500 nM
The estimate for compound 3 lay 9.3-fold (0.97 log units) below the measured number, and the stated range ends below it.
By their numbers in this assay, from the lowest: compounds 2 and 1 (each within the scatter of the next); then compound 3.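

The group on the amide-type nitrogen does move the number in this assay: 1,3-thiazol-2-yl in place of pyridin-4-yl gives an 8.1-fold higher number from compound 2 to compound 3 (0.91 log units; beyond the scatter), whereas the earlier exchange stayed within the scatter. The same group in place of 2-hydroxyphenyl gives a 5.0-fold higher number from compound 1 to compound 3 (0.70 log units; beyond the scatter), so among these three groups, only 1,3-thiazol-2-yl separates from the others. Nothing available bears on the reason for this separation.

Open, as far as these compounds go, is whether the higher number goes with the five-membered ring or with the sulfur. Also open, from the compounds shown here alone, is where a plain phenyl or a piperidin-4-yl on this nitrogen would fall.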